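The source may report more compounds than this note shows. Statements on the series, on what has been measured and on what is new or still open speak of the compounds shown alone.

Compound 2 `C#CCN(c1ccc(Cl)cc1C)S(=O)(=O)c1cc(Cl)ccc1Cl` belongs to a small set of sulfonamides built on a shared core, and it is judged in an ADME assay on A549 cells (Homo sapiens) for cytotoxicity, read by MTT assay; a lower number here means that less compound is tolerated, a higher number that more compound is tolerated. In this assay compound 2 returns only a limit of the assay, > 5000 nM, not a number. Its closest measured neighbour is compound 1 `CCN(c1ccc(Cl)cc1C)S(=O)(=O)c1cc(Cl)ccc1Cl`, which carries an ethyl group where compound 2 carries a propargyl group. In this assay compound 1 likewise gives only a limit, > 5000 nM. The step from compound 1 to compound 2 therefore cannot be read, a step that the two limits leave unreadable from compound 1 to compound 2, and the only thing the data show is the limit of > 5000 nM in this assay, at which 2 of the 2 values shown sit.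

Compound 3 `Cc1cc(Cl)ccc1N(CC1CC1)S(=O)(=O)c1cc(Cl)ccc1Cl` is the next member and has not yet been measured. It differs from compound 2 in one place: cyclopropyl in place of ethynyl on a saturated chain carbon bound to a sulfonamide nitrogen. For the measured compounds named here, no measured step resolves a change at this position, so the expectation rests on the fact that both neighbours sit at the limit. Compound 3 is therefore expected to behave the same way, meaning an estimated step that the limit leaves unreadable from compound 2 to compound 3 and a value around 6000 nM, most likely reported again as a limit, with the estimate ranging from 3000 nM to 20000 nM.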

Compound 3, half-maximal cytotoxic concentration: > 5000 nM
Compound 3 gave a limit, no number; the forecaster's own chance of this, stated with the estimate: 80%; the middle value does not contradict the limit.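

Compound 3 also returns a limit of the assay rather than a number, so no step among compound 1, compound 2 and compound 3 can be read, and the only thing the data show is this: the limit of > 5000 nM in this assay, at which 3 of the 3 values shown sit.

The compounds shown leave open whether any change at this chain position alters how much compound is tolerated in this assay.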